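The source may report more compounds than this note shows. Statements on the series, on what has been measured and on what is new or still open speak of the compounds shown alone.

In a functional assay on MDA-MB-231 cells (Homo sapiens) for antiproliferative activity, read by sulforhodamine B assay, with a stated time of 48 h (a lower number here means a stronger inhibitor of growth, a higher number a weaker inhibitor of growth), three compounds with a common core have been measured. Compound 1 (`Cc1ccc(-c2cn(CCCN3C(=O)COc4ccccc43)nn2)cc1`) gives 1120 nM, compound 2 (`COc1ccc2cc(-c3cn(CCCN4C(=O)COc5ccccc54)nn3)ccc2c1`) gives 5000 nM, and compound 3 (`COc1ccc(-c2cn(CCCN3C(=O)COc4ccccc43)nn2)cc1`) gives 41500 nM, the highest number of the three. Compound 4 (`CCCCc1cn(CCCN2C(=O)COc3ccccc32)nn1`) has butyl in place of 4-methoxyphenyl on an aromatic carbon of the five-membered aromatic ring with 3 nitrogen: butyl in place of 4-methoxyphenyl on an aromatic carbon. For the measured compounds named here, only one measured step comes close to this change: a 37-fold higher number from compound 1 to compound 3 (1.57 log units; beyond the scatter), a large step with methoxy in place of methyl on an aromatic carbon. Going by the values given here, that step shows how far the number can move with a small substitution, but no measured compound lacks the aromatic ring at this place, so the direction remains uncertain. Compound 3 stands at the top of the measured numbers, while compound 2 at 5000 nM lies lower, so a fall is expected to be more likely than a rise. The expected step is a 4.2-fold lower number from compound 3 to compound 4 (0.62 log units; beyond the scatter), moderate and with wide uncertainty. For compound 4 the estimated value is 10000 nM, with an expected range from 2000 nM to 50000 nM.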

Compound 4, concentration for 50% growth inhibition: 3600 nM
For compound 4 the middle estimate is 2.8-fold (0.44 log units) above the measured one; measured number inside the range.
By their numbers in this assay, from the lowest: compound 1; then compounds 4 and 2 (each within the scatter of the next); then compound 3.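

In this assay, putting butyl in place of 4-methoxyphenyl gives a 12-fold lower number from compound 3 to compound 4 (1.06 log units; beyond the scatter), so a chain with no ring can stand on this aromatic carbon of the five-membered aromatic ring with 3 nitrogen and growth inhibition is kept. Butyl in place of 4-methylphenyl gives a 3.2-fold higher number from compound 1 to compound 4 (0.51 log units; beyond the scatter), so the butyl compound falls between the two compounds that carry a substituted phenyl here, and a six-membered aromatic ring at this place does not by itself set the number: it depends on the substituent that ring carries. No data on hand explain either step.

The compounds shown leave open how a shorter or longer chain than butyl, a branched chain, or a chain ending in an amine or a hydroxyl would fare on this carbon. They also leave open how a saturated ring such as cyclohexyl would compare with the 4-methylphenyl of compound 1.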